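The source may report more compounds than this note shows. Statements on the series, on what has been measured and on what is new or still open speak of the compounds shown alone.

Values in an ADME assay on microsomes from liver (Homo sapiens) for metabolic stability, read by LC-MS, using NADPH, with a stated time of 10 min, tested at 0.1 uM; a higher number here means faster removal of the compound, a lower number slower removal:
- compound 1 `COc1ccccc1N1C(=O)CSC1c1cc(F)cc(C(=O)NCCCCc2ccccc2)c1`: 2080 mL.min-1.g-1
- compound 2 `COc1ccc(F)cc1N1C(=O)CSC1c1cccc(C(=O)NCCCCc2ccccc2)c1`: 1250 mL.min-1.g-1

Compound 2, at 1250 mL.min-1.g-1, lies within the scatter of compound 1, at 2080 mL.min-1.g-1, so neither stands apart in this assay.

Compound 3 `O=C(NCCCCc1ccccc1)c1cccc(C2SCC(=O)N2c2ccccn2)c1` carries pyridin-2-yl in place of 5-fluoro-2-methoxyphenyl on an amide-type nitrogen in a ring. Among the measured compounds shown here, the measured compounds include no step for this change, so the expectation is only a judgement: a small fall in this assay, within the scatter. The estimated change is a 1.6-fold lower number from compound 2 to compound 3 (0.19 log units; within the scatter). Compound 3 is expected at 800 mL.min-1.g-1, with an estimated range of 300 mL.min-1.g-1 to 1800 mL.min-1.g-1.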

Compound 3, intrinsic clearance in microsomes: 412 mL.min-1.g-1
Estimate against measurement, compound 3: 1.9-fold (0.29 log units) above; the range from low to high includes it.
By their numbers in this assay, from the lowest: compound 3; then compounds 2 and 1 (each within the scatter of the next).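

Among the compounds shown here, with pyridin-2-yl in place of 5-fluoro-2-methoxyphenyl on the amide-type nitrogen in the ring, this assay shows a 3.0-fold lower number from compound 2 to compound 3 (0.48 log units; beyond the scatter), the only step so far. The number at this position therefore responds to the group it carries, which compound 1 and compound 2 could not show, as they differ in more than one place. Nothing at hand gives a reason for this step.

Going by these compounds, the change replaces the whole group, so the part played by the ring nitrogen, the methoxy and the fluorine stays open. Also open, on these data alone, is how pyridin-3-yl or unsubstituted phenyl would stand here.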